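One Chlorine Kept, One Removed: Estimating Compound 4

This account rests on a few compounds, and the source may have more. Where it says the series, first, only, none or still open, it means among the compounds named here.

Compound 1 `COc1cc(Nc2ncnc3c(NC(=O)Nc4cc(Cl)cc(Cl)c4)cccc23)cc(OC)c1` gives the lowest number among the compounds measured in a functional assay on RT-112 cells (Homo sapiens) for antiproliferative activity, read by MTT assay, with a stated time of 72 h (a lower number here means a stronger inhibitor of growth, a higher number a weaker inhibitor of growth), at 30.2 nM. Compound 2 `COc1cc(Nc2ncnc3c(NC(=O)Nc4cc(C(F)(F)F)cc(C(F)(F)F)c4)cccc23)cc(OC)c1` gives 467 nM in this assay, a clearly weaker result. Compound 3 `COc1cc(Nc2ncnc3c(NC(=O)Nc4ccc(C(F)(F)F)cc4[N+](=O)[O-])cccc23)cc(OC)c1` reaches only a limit of the assay, > 20000 nM, so no number is available for it (the limit of > 20000 nM in this assay, at which 1 of the 3 values shown sits). Compound 4 `COc1cc(Nc2ncnc3c(NC(=O)Nc4ccc(Cl)cc4)cccc23)cc(OC)c1` has not yet been measured. It differs from compound 1 in one place: 4-chlorophenyl in place of 3,5-dichlorophenyl on an amide-type nitrogen. Within the data shown here, no measured pair shows this exact change, so only a cautious expectation is possible. For compound 4 the expected step is a 5.0-fold higher number from compound 1 to compound 4 (0.70 log units; beyond the scatter), an estimated loss of some potency while the compound is expected to stay active. The estimated value of compound 4 is 150 nM, within an expected range from 40 nM to 800 nM.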

Compound 4, concentration for 50% growth inhibition: 2490 nM
For compound 4 the middle estimate is 17-fold (1.22 log units) below the measured one; the whole stated range lies below it.
By their numbers in this assay, from the lowest: compound 1; then compound 2; then compound 4. At a limit, above all of these: compound 3.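

In this assay, replacing 3,5-dichlorophenyl with 4-chlorophenyl on the amide-type nitrogen gives an 82-fold higher number from compound 1 to compound 4 (1.92 log units; beyond the scatter). This shows that activity depends strongly on how chlorine is arranged on this ring, even when the ring itself stays and only one chlorine is lost. Nothing shown here explains this loss.

Compound 4 both loses one chlorine and carries the remaining one at a different place, and these two changes cannot be separated here. From the compounds shown here alone, how a plain phenyl ring, or one bearing methyl or methoxy groups instead of chlorine, would behave remains open.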